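Ethylcarbamoyl in Place of Pyridin-4-yl: Expected Inhibition

The compounds below may be only part of what the source reports. "The series", "measured", "known", "first", "only" and "open" are said of these compounds alone.

Compound 1 `COc1ccc(OC)c(S(=O)(=O)Nc2cncc(-c3ccncc3)c2)c1`: in an assay on isolated protein for inhibition of alkaline phosphatase, tissue-nonspecific isozyme (Homo sapiens) (a lower number here means a stronger inhibitor, a higher number a weaker inhibitor), compound 1 gives > 20000 nM, a limit of the assay and not a number.
Compound 2 `COc1ccc(Cl)cc1S(=O)(=O)Nc1cncc(-c2ccncc2)c1`: in this assay compound 2 gives > 20000 nM, again a limit.
Compound 3 `COc1ccc(C(N)=O)cc1S(=O)(=O)Nc1cccnc1`: in this assay compound 3 gives "not determined" (no result reported).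

Compound 2 therefore stands only at a limit in this assay; one further value is likewise a limit, and one entry carries no number at all. Among the compounds with values here, the single step between measured compounds, from compound 1 to compound 2, is a step that the two limits leave unreadable from compound 1 to compound 2, its size hidden by the limit of > 20000 nM in this assay, at which 2 of the 3 values shown sit.

Compound 4 `CCNC(=O)c1cncc(NS(=O)(=O)c2cc(Cl)ccc2OC)c1` differs from compound 2 by ethylcarbamoyl in place of pyridin-4-yl on an aromatic carbon. No measured step reads out a size, so nothing bears on this change in a readable way, and the step that the limit leaves unreadable from compound 2 to compound 4 is an estimate resting only on the limits shown. Compound 4 is expected to remain around 30000 nM in this assay, within 5000 nM to 200000 nM, most likely reported as a limit.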

Compound 4, half-maximal inhibitory concentration: > 20000 nM
Compound 4 gave a limit, no number; the forecaster's own chance of this, stated with the estimate: 80%; the middle value lies beyond the limit too.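

No step can be read from compound 2 to compound 4, because neither compound gives a number: the limit of > 20000 nM in this assay, at which 3 of the 4 values shown sit.

The compounds shown leave open how ethylcarbamoyl and pyridin-4-yl compare on the shared core, and which change, if any, would bring a readable inhibition.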